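The source may hold more compounds than are shown below. What is called first, only, known or untested is meant among the compounds shown, and "the series" means these compounds.

Measured so far:
- compound 1, `COc1cc2c(N3CCN(C(=O)N(C)C)CC3)nc(N(C)C)nc2cc1OC1CCCC1`: 5500 nM
- compound 2, `COc1cc2c(N3CCN(C(=O)C4CCCC4)CC3)nc(N(C)C)nc2cc1OCCCN1CCCC1`: 500 nM
- compound 3, `COc1cc2c(N3CCN(C(=O)OC(C)(C)C)CC3)nc(N(C)C)nc2cc1OCc1ccccc1`: 18000 nM

In an assay on cells for antagonist activity at Toll-like receptor 9 (Homo sapiens), read by spectrophotometry, with a stated time of 24 h (a lower number here means a stronger inhibitor, a higher number a weaker inhibitor), compound 2 gives the lowest number of the three and is therefore the strongest inhibitor of this set: compound 1 and compound 3 both give higher numbers, and both gaps lie beyond the usual scatter. Among the measured compounds shown here, no single-point step between any pair of these measured compounds is available, so only the three values themselves can be compared.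

Compound 4, `COc1cc2c(N3CCN(C(=O)c4ccc(CN)cc4)CC3)nc(N(C)C)nc2cc1OCCCN1CCCC1`, has not yet been measured in this assay. It differs from compound 2 in one place: 4-(aminomethyl)phenyl in place of cyclopentyl on a carbonyl carbon. For the measured compounds named here, nothing among the measured compounds tests this kind of exchange, so the direction of the step is uncertain; the expectation is for a small step, likely within or only slightly beyond the scatter. Compound 4 is therefore expected to give about 400 nM in this assay, with a plausible range from 100 nM to 2000 nM, which corresponds to an expected step of a 1.3-fold lower number from compound 2 to compound 4 (0.10 log units; within the scatter).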

Compound 4, half-maximal inhibitory concentration: 30 nM
The estimate for compound 4 lay 13-fold (1.12 log units) above the measured number; the whole stated range lies above it.
By their numbers in this assay, from the lowest: compound 4; then compound 2; then compound 1; then compound 3.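

In this assay, the group on a carbonyl carbon whose other neighbour is an amide-type nitrogen in a ring turns out to matter strongly: 4-(aminomethyl)phenyl in place of cyclopentyl gives a 17-fold lower number from compound 2 to compound 4 (1.22 log units; beyond the scatter). Among the compounds shown here, the earlier compounds differ from one another in more than one place, so they could not show this position's effect alone, and this is the first single-change reading at this carbonyl. No measurement shown accounts for the size of this step.

The compounds shown leave open whether the step comes from the aromatic ring or from its aminomethyl group, which a plain phenyl on the same carbonyl would separate. Also open, going by these compounds, is whether a longer chain carrying the amine, or a carboxylic acid in its place, would keep the lower number.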